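This account rests on a few compounds, and the source may have more. Where it says the series, first, only, none or still open, it means among the compounds named here.

Working notes on the series. Compound 1 `COc1ccccc1/C=c1/[nH]c(=O)/c(=C\c2ccccc2OC)[nH]c1=O` carries two 2-methoxyphenyl groups and in a functional assay on HeLa cells (Homo sapiens) for cytotoxicity, read by CCK-8 assay, with a stated time of 72 h (a lower number here means a stronger inhibitor, a higher number a weaker inhibitor), compound 1 is reported as "not active" (no number reported), with no number given. Compound 2 `C=CCn1c(=O)/c(=C\c2cc(F)ccc2C)[nH]c(=O)/c1=C\c1ccccc1OC` in this assay gives 2900 nM. Within the data shown here, compound 3 `C=CCn1c(=O)/c(=C\c2ccccc2OC)[nH]c(=O)/c1=C\c1ccccc1OC` in this assay gives 6900 nM; among the two compounds with a number, compound 3 stands at the higher one, and the one step that reaches it is a 2.4-fold higher number from compound 2 to compound 3 (0.38 log units; beyond the scatter).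

Compound 4 `C=CCn1c(=O)/c(=C\c2ccc(Cl)c(Cl)c2)[nH]c(=O)/c1=C\c1ccccc1OC` has not yet been measured. The change from compound 3 is 3,4-dichlorophenyl in place of 2-methoxyphenyl on a double-bonded chain carbon bound to an aromatic carbon. Among the measured compounds shown here, the only step that bears on it is a 2.4-fold higher number from compound 2 to compound 3 (0.38 log units; beyond the scatter), which shows that exchanging 2-methoxyphenyl for another aryl group at this place moved the number by a modest amount, and compound 1, with 2-methoxyphenyl on both sides, gave no measurable number. For the measured compounds named here, a step of similar size, toward a lower number, is therefore expected for compound 4, with wide uncertainty since 3,4-dichlorophenyl has no counterpart among the measured compounds. Compound 4 is expected to give about 3500 nM, within 1200 nM to 10000 nM, an expected step of a 2.0-fold lower number from compound 3 to compound 4 (0.29 log units; within the scatter).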

Compound 4, half-maximal inhibitory concentration: "not active" (no number reported)
The entry for compound 4 holds no number, and the estimate cannot be compared.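

In this assay, among these compounds, compound 4 gives "not active" (no number reported) and so no step from compound 3 to compound 4 can be read. No available evidence bears on this result. The compounds shown leave open whether compound 4 and compound 1 have any activity at higher concentrations.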